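The source may report more compounds than this note shows. Statements on the series, on what has been measured and on what is new or still open speak of the compounds shown alone.

Compound 1 `O=C(CSc1nc(Nc2ccccc2)c2ccccc2n1)Nc1ccccc1Br` gives 10300 nM in a functional assay on NCI-H1975 cells (Homo sapiens) for inhibition, read by MTT assay, with a stated time of 72 h; on this read-out lower numbers stand for stronger inhibition and higher numbers for weaker inhibition.
Compound 2 `O=C(CSc1nc(Nc2ccccc2)c2ccccc2n1)Nc1cccc(Br)c1` gives 10100 nM in this assay.
Compound 3 `O=C(CSc1nc(Nc2ccccc2)c2ccccc2n1)Nc1ccc([N+](=O)[O-])cc1` gives 13000 nM in this assay.

All three compounds share the same core and differ only in the ring attached to the amide nitrogen. On the numbers shown, compound 3 sits nearest the high end of the three, but every step between these compounds is small: a 1.0-fold lower number from compound 1 to compound 2 (0.01 log units; within the scatter), a 1.3-fold higher number from compound 1 to compound 3 (0.10 log units; within the scatter) and a 1.3-fold higher number from compound 2 to compound 3 (0.11 log units; within the scatter). Within the data shown here, none of them lies beyond the scatter, so no compound can be called weaker or stronger than another.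

Compound 4 `O=C(CSc1nc(Nc2ccccc2)c2ccccc2n1)Nc1ccc(C(F)(F)F)cc1` differs from compound 3 by trifluoromethyl in place of nitro on an aromatic carbon. This change sits on the same ring where the earlier changes took place. Those earlier changes, swapping bromine between two positions or replacing bromine with nitro, all left the numbers in this assay within the scatter. On that basis, replacing nitro with trifluoromethyl is expected to produce no step beyond the scatter in either direction. Compound 4 is therefore expected to give about 11000 nM in this assay, with a range from 5000 nM to 25000 nM. This estimate corresponds to an expected step of a 1.2-fold lower number from compound 3 to compound 4 (0.07 log units; within the scatter).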

Compound 4, half-maximal inhibitory concentration: 11700 nM
The estimate for compound 4 lay 1.1-fold (0.03 log units) below the measured number; the range from low to high includes it.
By their numbers in this assay, from the lowest: compounds 2, 1, 4 and 3 (each within the scatter of the next).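

In this assay, the exchange of nitro for trifluoromethyl is the first change shown that keeps the position fixed, on an aromatic carbon para to a large group, and alters only the group standing there (a 1.1-fold lower number from compound 3 to compound 4 (0.05 log units; within the scatter)). The exchange removes a group that counts as two hydrogen-bond acceptors and brings in one that counts as none, yet this difference in the drawn structures comes with no step beyond the scatter, and the comparisons with the two bromine compounds (a 1.2-fold higher number from compound 2 to compound 4 (0.06 log units; within the scatter)) and (a 1.1-fold higher number from compound 1 to compound 4 (0.06 log units; within the scatter)) stay within it as well. Nothing measured here explains why the number holds so steady across these groups.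

On these data alone, what remains open is whether this ring position responds at all to groups of a different kind, such as an amine, a carboxylic acid or a longer chain such as a butyl group. The four compounds also share the rest of their structure unchanged, so they leave open what a change elsewhere on the shared core, for example replacing its unsubstituted phenyl ring with a pyridine, would do in this assay.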